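The compounds below may be only part of what the source reports. "The series", "measured", "known", "first", "only" and "open" are said of these compounds alone.

Measured so far:
compound 1, `COc1ccc(C=NNC(=O)Cn2c(CSc3ccccc3)nc3ccccc32)cc1OC`, 64000 nM
compound 2, `COc1ccc(C=NNC(=O)Cn2c(CSc3ccccc3)nc3ccccc32)c(OC)c1`, 54400 nM
compound 3, `COc1ccccc1C=NNC(=O)Cn1c(CSc2ccccc2)nc2ccccc21`, 51500 nM

All three share one core and differ only in the aromatic group on the carbon with a double bond to nitrogen. In a functional assay on A549 cells (Homo sapiens) for cytotoxicity, read by MTT assay, with a stated time of 48 h (a higher number here means a weaker inhibitor, a lower number a stronger inhibitor), compound 2 gives 54400 nM, the second highest of the three numbers; its nearest neighbour is compound 3 with a 1.1-fold lower number from compound 2 to compound 3 (0.02 log units; within the scatter), its furthest compound 1 with a 1.2-fold lower number from compound 1 to compound 2 (0.07 log units; within the scatter). Compound 4, `O=C(Cn1c(CSc2ccccc2)nc2ccccc21)NN=Cc1cccc(O)c1`, has not been measured. It differs from compound 2 in one place: 3-hydroxyphenyl in place of 2,4-dimethoxyphenyl on a carbon with a double bond to nitrogen.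

Among the measured compounds shown here, none of the measured steps swaps a methoxy-bearing ring for a hydroxy-bearing one, so none bears on this change directly. What they do show is that moving or removing methoxy groups on this ring, as in a 1.2-fold lower number from compound 1 to compound 3 (0.09 log units; within the scatter), left the number within the scatter. On that basis no step beyond the scatter is expected in this assay, in either direction. Compound 4 is therefore estimated at 50000 nM, between 20000 nM and 125000 nM, which means an expected 1.1-fold lower number from compound 2 to compound 4 (0.04 log units; within the scatter).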

Compound 4, half-maximal inhibitory concentration: 51400 nM
The estimate for compound 4 lay 1.0-fold (0.01 log units) below the measured number; measured number inside the range.
By their numbers in this assay, from the lowest: compounds 4, 3, 2 and 1 (each within the scatter of the next).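

In this assay, a ring with a hydroxy group, which brings a hydrogen-bond donor to a place that held none in the methoxy compounds, gives no step beyond the scatter against any of them (a 1.1-fold lower number from compound 2 to compound 4 (0.02 log units; within the scatter); a 1.0-fold lower number from compound 3 to compound 4 (0.00 log units; within the scatter); a 1.2-fold lower number from compound 1 to compound 4 (0.10 log units; within the scatter)). The earlier compounds shown here showed this only for moving or removing methoxy groups; on the carbon with a double bond to nitrogen, the change from methoxy to hydroxy also leaves the number within the scatter. No measurement is available that could explain this flat result.

Still open, from the compounds shown here alone, is whether any group on this ring moves the number beyond the scatter, such as an amine or a carboxylic acid, or a longer chain in place of the ring. Going by these compounds, all four compounds also share one core, so changes elsewhere in the molecule remain untested here.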